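The source may report more compounds than this note shows. Statements on the series, on what has been measured and on what is new or still open speak of the compounds shown alone.

Measured so far:
- compound 1 `COCc1nc2nc(C)cc(Nc3ccc(C(F)(F)F)cc3)n2n1`: 6.7 mL.min-1.g-1
- compound 2 `Cc1cc(Nc2ccc(S(F)(F)(F)(F)F)cc2)n2nc(C3CC3)nc2n1`: < 5 mL.min-1.g-1 (a limit of the assay)

For the measured compounds named here, in an in vitro ADME assay on microsomes from liver (Homo sapiens) for metabolic stability (a lower number here means slower removal, a higher number faster removal of the compound), compound 1 gives 6.7 mL.min-1.g-1, the only actual number so far. Compound 2 stands at < 5 mL.min-1.g-1, which is a limit of the assay and not a number.

The next compound is compound 3 `CSc1nc2nc(C)cc(Nc3ccc(C(F)(F)F)cc3)n2n1`, which has methylsulfanyl in place of methoxymethyl on an aromatic carbon of the shared core (methylsulfanyl in place of methoxymethyl on an aromatic carbon). Nothing else in the core of compound 1 changes. Going by the values given here, no measured pair shows this exchange, so the expectation is loose: a small rise in this assay, close to the usual scatter. The expected step is a 1.2-fold higher number from compound 1 to compound 3 (0.08 log units; within the scatter). In this assay the estimate for compound 3 is 8 mL.min-1.g-1, with an expected range of 4 mL.min-1.g-1 to 16 mL.min-1.g-1.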

Compound 3, intrinsic clearance in microsomes: 18.7 mL.min-1.g-1
Beside the measured number, compound 3's estimate is 2.3-fold (0.37 log units) below it, outside the stated range (above it).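

In this assay, the aromatic carbon of the five-membered aromatic ring with 3 nitrogen, between two ring nitrogen atoms, now has its first readable exchange: methylsulfanyl in place of methoxymethyl gives a 2.8-fold higher number from compound 1 to compound 3 (0.45 log units; beyond the scatter). This shows that the number at this position responds to the group placed there, since the step lies beyond the scatter while the rest of the core of compound 1 stays unchanged. Nothing measured here accounts for the rise.

For the compounds shown here, compound 2 stands at < 5 mL.min-1.g-1, a limit of the assay and not a number, and it differs from compound 1 in more than one place, so it adds no step. Going by these compounds alone, with only one pair, it remains open where an amine or a longer chain at this position would fall in this assay, and whether the same exchange gives a similar step on a different core.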